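The source may report more compounds than this note shows. Statements on the series, on what has been measured and on what is new or still open speak of the compounds shown alone.

Measured compounds: compound 1 `COc1ccc(/C=C/C2CC=CC(=O)O2)cc1` gives 61.5 uM in a functional assay on OVCAR-3 cells (Homo sapiens) for inhibition, read by sulforhodamine B assay, with a stated time of 48 h; a lower number here means a stronger inhibitor of growth, a higher number a weaker inhibitor of growth; compound 2 `COc1ccc(/C=C/C2CC=CC(=O)O2)c(OC)c1` gives 5.6 uM; compound 3 `COc1cc(/C=C/C2CC=CC(=O)N2)cc(OC)c1` gives 232 uM.

The shared core of compound 1 and compound 3 is not the same, and the difference between the two cores is not broken down here. The step methoxy in place of hydrogen on an aromatic carbon brought an 11-fold lower number from compound 1 to compound 2 (1.04 log units; beyond the scatter). Compound 4 `COc1cc(/C=C/C2CC=CC(=O)N2)cc(OC)c1OC` is not yet measured; it arises from compound 3 by methoxy in place of hydrogen on an aromatic carbon. Among the measured compounds shown here, this is the same kind of change as the one from compound 1 to compound 2, but the place differs: the earlier methoxy went ortho to a group of 9 heavy atoms and meta to a methoxy group, whereas the new one goes ortho to two methoxy groups and para to a group of 9 heavy atoms. For compound 4 the step of a 2.9-fold lower number from compound 3 to compound 4 (0.46 log units; beyond the scatter) in this assay is expected, smaller than the earlier one because an 11-fold lower number from compound 1 to compound 2 (1.04 log units; beyond the scatter) sat at a different place. Compound 4 is estimated at 80 uM, between 25 uM and 250 uM.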

Compound 4, concentration for growth inhibition (reported as GI): > 864 uM
Compound 4 was reported as a limit; the forecaster's own chance of this, stated with the estimate: 10%; at least 10-fold (1.03 log units) between middle value and limit.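

In this assay, methoxy in place of hydrogen on an aromatic carbon gave an at least 3.7-fold higher number from compound 3 to compound 4 (0.57 log units; beyond the scatter), a change in the opposite direction to the earlier step on the core of compound 1. From the compounds shown here alone, compound 4 gives > 864 uM, which is a limit of the assay and not a number, so the full size of this step remains unknown. The change therefore did not carry over from one core to the other, but both the core and the place on the ring differ, and these compounds cannot separate those two differences: the same change on two cores in this assay, an 11-fold lower number (1.04 log units; beyond the scatter) from compound 1 to compound 2 and an at least 3.7-fold higher number (0.57 log units; beyond the scatter) from compound 3 to compound 4, at least 40-fold (1.61 log units) apart, beyond the scatter of two such steps.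

Going by these compounds, it remains open how a methoxy group would act on the core of compound 3 at the place it holds in compound 2. Also open, on these data alone, is whether a hydroxy group or a chlorine atom, ortho to two methoxy groups, would give the same result as methoxy.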